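This account rests on a few compounds, and the source may have more. Where it says the series, first, only, none or still open, it means among the compounds named here.

Measured so far:
- compound 1, `COC(C)(C)[C@@H](O)C(=O)N1N=CC[C@H]1C(=O)NCc1cc(Cl)ccc1-n1cnnn1`: 3700 nM in a functional assay on a cell-free system (plasma, Homo sapiens), with a stated time of 3 min; on this read-out higher numbers stand for weaker inhibition and lower numbers for stronger inhibition
- compound 2, `O=C(NCc1cc(Cl)ccc1-n1cnnn1)[C@@H]1[C@@H]2C[C@@H]2CN1C(=O)[C@H](O)c1ccccc1`: 700 nM in this assay

Of the compounds shown here, two have been measured. In this assay compound 1 gives 3700 nM, the higher of the two numbers. Compound 2, whose structure is `O=C(NCc1cc(Cl)ccc1-n1cnnn1)[C@@H]1[C@@H]2C[C@@H]2CN1C(=O)[C@H](O)c1ccccc1`, gives 700 nM in this assay, a lower number, and the gap between the two lies beyond the usual scatter of repeated measurements. Among the measured compounds shown here, no step between these two compounds is set out, as they differ in more than one place, so only their two values are compared here.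

The next compound is compound 3, `CC(C)(C)C[C@@H](O)C(=O)N1N=CC[C@H]1C(=O)NCc1cc(Cl)ccc1-n1cnnn1`. It differs from compound 1 in one place: neopentyl in place of 1-methoxy-1-methylethyl on a saturated chain carbon bound to a carbonyl carbon and an oxygen on a saturated carbon. The change keeps the same count of heavy atoms on the chain and removes the only hydrogen-bond acceptor of the group that leaves.

For the measured compounds named here, with no measured step of this kind to lean on, a step of modest size is expected, if any, and it is estimated at a 1.5-fold lower number from compound 1 to compound 3 (0.17 log units; within the scatter) in this assay. Compound 3 is accordingly expected to give about 2500 nM in this assay, within a range from 900 nM to 7000 nM.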

Compound 3, half-maximal inhibitory concentration: 590 nM
The estimate for compound 3 lay 4.2-fold (0.63 log units) above the measured number, and the stated range ends above it.
By their numbers in this assay, from the lowest: compounds 3 and 2 (each within the scatter of the next); then compound 1.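

In this assay, putting neopentyl in place of 1-methoxy-1-methylethyl on a saturated chain carbon bound to a carbonyl carbon and an oxygen on a saturated carbon gives a 6.3-fold lower number from compound 1 to compound 3 (0.80 log units; beyond the scatter) in a single change. Among the compounds shown here, this is the first step measured at this position, and it shows that the number there depends on what the group is made of, not only on its size: both groups have the same count of heavy atoms and neither has a ring, yet the group that enters has carbon where the one that leaves has oxygen, and it has no hydrogen-bond acceptor. Nothing measured here says why the number falls with this change.

With one pair at this position, the compounds shown leave open whether the number would keep falling, level off or rise with a longer chain, a smaller ethyl group, an amine or a carboxylic acid in the same place. They also leave open whether neopentyl would give a step of similar size on the core of compound 2, which differs from compound 1 in more than one place.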